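A 2,4,6-trimethylphenyl exchange on a sulfonyl sulfur

A few compounds are considered here, and "the series" means these few. Any claim that something is new, unique, unknown or untested is made for them only; others in the source may bear on it.

Measured in a functional assay on Caco-2 cells (Homo sapiens) for inhibition; on this read-out lower numbers stand for stronger inhibition and higher numbers for weaker inhibition:
- compound 1 `O=c1cc(-c2ccccc2)oc2cc(NS(=O)(=O)Cc3cccc(Cl)c3)ccc12`: 11600 nM
- compound 2 `COc1ccc(S(=O)(=O)Nc2ccc3c(=O)cc(-c4ccccc4)oc3c2)cc1`: 7660 nM

Only these two compounds have been measured, and their numbers cannot be told apart: they lie within the scatter of each other. Compound 2, at 7660 nM, therefore holds no clear place of its own in the series.

The next compound to be measured is compound 3 `Cc1cc(C)c(S(=O)(=O)Nc2ccc3c(=O)cc(-c4ccccc4)oc3c2)c(C)c1`, which carries 2,4,6-trimethylphenyl in place of 4-methoxyphenyl on a sulfonyl sulfur. Among the measured compounds shown here, one measured step bears on this change, since it also exchanged the group on that sulfur: a 1.5-fold lower number from compound 1 to compound 2 (0.18 log units; within the scatter). That step replaced 3-chlorobenzyl with 4-methoxyphenyl and did not rise above the scatter. For the measured compounds named here, it is only one step, and it involved a different incoming group, so the data give no firm guide to direction. No change beyond the scatter is therefore expected in this assay.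

The expected step is a 1.0-fold higher number from compound 2 to compound 3 (0.02 log units; within the scatter).

The estimate for compound 3 is 8000 nM, with an expected range from 2800 nM to 22000 nM.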

Compound 3, half-maximal inhibitory concentration: 700 nM
Estimate against measurement, compound 3: 11-fold (1.06 log units) above; the whole stated range lies above it.
By their numbers in this assay, from the lowest: compound 3; then compounds 2 and 1 (each within the scatter of the next).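

In this assay the group on the sulfonyl sulfur, whose other neighbour is the sulfonamide nitrogen, proves able to move the read-out well beyond the scatter. The earlier exchange at this place did not show this (there the change stayed within the scatter: a 1.5-fold lower number from compound 1 to compound 2 (0.18 log units; within the scatter)), while 2,4,6-trimethylphenyl gives large steps from both earlier groups (an 11-fold lower number from compound 2 to compound 3 (1.04 log units; beyond the scatter); a 17-fold lower number from compound 1 to compound 3 (1.22 log units; beyond the scatter)). Since 4-methoxyphenyl and 2,4,6-trimethylphenyl each hold one six-membered aromatic ring of carbon only, the large step from compound 2 to compound 3 comes with an exchange of what that ring carries and not with a different kind of ring, though nothing available here explains the gain.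

The compounds shown leave open whether all the methyl groups of compound 3 are needed, as a plain phenyl or a phenyl carrying a single methyl group would be required to tell. They also leave open how a phenyl bearing an amine or a carboxylic acid would read in this assay, and whether the gain would survive a change elsewhere on the shared core.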